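Series notes: one chloro removed from the shared core

A few compounds are considered here, and "the series" means these few. Any claim that something is new, unique, unknown or untested is made for them only; others in the source may bear on it.

Measured so far in a functional assay on NCI-H322M cells (Homo sapiens) for cytotoxicity, read by sulforhodamine B assay, with a stated time of 48 h; a higher number here means a weaker inhibitor of growth, a lower number a stronger inhibitor of growth:
- compound 1, `ClCc1cccc(Cn2cnc3c(Cl)ncnc32)c1`, gives 3460 nM
- compound 2, `ClCc1ccc(Cn2cnc3nc(Cl)nc(Cl)c32)cc1`, gives 1900 nM
- compound 3, `ClCc1cccc(Cn2cnc3c(Cl)nc(Cl)nc32)c1`, gives 5120 nM

Compound 3 and compound 1 differ in one place: hydrogen in place of chloro on an aromatic carbon. The step is a 1.5-fold lower number from compound 3 to compound 1 (0.17 log units; within the scatter), so on the evidence of this pair the change does little to the read-out. Compound 2 and compound 3 carry the same atoms joined differently; the difference between the two cores is not broken down here. Compound 2 gives a lower number than compound 3, a gap told as beyond the scatter, while compound 2 and compound 1 sit within the scatter of each other.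

Compound 4, `ClCc1ccc(Cn2cnc3ncnc(Cl)c32)cc1`, is not yet measured. It differs from compound 2 by hydrogen in place of chloro on an aromatic carbon. For the measured compounds named here, the place line for this change reads the same word for word as the one from compound 3 to compound 1, so it is the same change made on the core of compound 2. Going by the values given here, with only one measured example of the change, the expectation rests on that single step from compound 3 to compound 1 and on the value of compound 2. Compound 4 is therefore expected to land near compound 2, with the estimated step of a 1.4-fold lower number from compound 2 to compound 4 (0.13 log units; within the scatter), because the measured step of a 1.5-fold lower number from compound 3 to compound 1 (0.17 log units; within the scatter) was itself within the scatter. Among the compounds with values here, the estimate for compound 4 in this assay is 1400 nM, with a range from 600 nM to 3500 nM, the width reflecting that only one prior example of the change exists and that the two cores are not the same.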

Compound 4, concentration for total growth inhibition: 3010 nM
Compound 4: the middle estimate sits 2.2-fold (0.33 log units) below what was measured; measured number inside the range.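

In this assay, hydrogen in place of chloro on an aromatic carbon gives a 1.6-fold higher number from compound 2 to compound 4 (0.20 log units; within the scatter), so on this core, as on the earlier one, the change does little to the read-out. Set side by side, the two steps cannot be told apart: the same change on two cores in this assay, a 1.5-fold lower number (0.17 log units; within the scatter) from compound 3 to compound 1 and a 1.6-fold higher number (0.20 log units; within the scatter) from compound 2 to compound 4, 2.3-fold (0.37 log units) apart, within the scatter of two such steps. The two pairs therefore show that this change carries from one core to the other without a step beyond the scatter, but they do not fix a shared size or direction for it, since steps this small cannot be separated from repeat measurement, and two pairs set no rule for the wider series.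

The compounds shown compare only chloro and hydrogen at this place on the shared core, so it remains open whether an amine, a methoxy group or a thioether there would give a step beyond the scatter. Also open, as far as these compounds go, is how the read-out responds when the chloromethyl group, present in all four compounds, gives way to a hydroxymethyl group or a longer chain.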